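The source may report more compounds than this note shows. Statements on the series, on what has been measured and on what is new or still open speak of the compounds shown alone.

The series shares one core, seen in compound 1 `CC(/C=N/Nc1ccc([N+](=O)[O-])cc1)=N\NC(=O)c1ccccc1Nc1ccccc1`, compound 2 `CC(/C=N/Nc1ccc([N+](=O)[O-])cc1)=N\NC(=O)c1ccccc1N` and compound 3 `CC(/C=N/Nc1ccc([N+](=O)[O-])cc1)=N\NC(=O)c1ccccc1Oc1ccccc1`, and all three have been tested in an ADME assay on J774 cells (Mus musculus, strain BALB/c) for cytotoxicity, read by resazurin assay, with a stated time of 72 h; a higher number here means that more compound is tolerated, a lower number that less compound is tolerated. Compound 1 reaches only a limit of this assay, at > 100000 nM. Compound 3 likewise stands at a limit, > 100000 nM. Within the data shown here, compound 2 is the only member with a number of its own, giving 29800 nM in this assay, and so it is the one compound whose value can be read directly.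

Compound 4 `CC(/C=N/Nc1ccc([N+](=O)[O-])cc1)=N\NC(=O)c1ccc(Cl)cc1` has not yet been measured. It differs from compound 2 in one place: 4-chlorophenyl in place of 2-aminophenyl on a carbonyl carbon. Among the measured compounds shown here, two measured steps touch on that change. The step of an at least 3.3-fold lower number from compound 1 to compound 2 (0.52 log units; beyond the scatter) shows that arriving at the free amino group brought the number down from a limit, and the step of an at least 3.3-fold higher number from compound 2 to compound 3 (0.52 log units; beyond the scatter) shows that replacing that amino group again sent the number back to a limit (the limit of > 100000 nM in this assay, at which 2 of the 3 values shown sit). Compound 4 also gives up the amino group, so a step upward in this assay is expected, of a size comparable to those two, and the value of compound 4 is expected to lie around 90000 nM, between 30000 nM and 250000 nM, which would mean an expected step of a 3.0-fold higher number from compound 2 to compound 4 (0.48 log units; beyond the scatter) and quite possibly only a limit again.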

Compound 4, half-maximal cytotoxic concentration: 63900 nM
Estimate against measurement, compound 4: 1.4-fold (0.15 log units) above, within the range that was stated.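

In this assay, leaving the 2-aminophenyl group on the carbonyl carbon now has a size that can be read, a 2.1-fold higher number from compound 2 to compound 4 (0.33 log units; beyond the scatter), and the step stays modest. The earlier steps shown here away from the amino compound gave only a lower bound on such a rise, since compound 1 and compound 3 each stand at a limit and not at a number: the limit of > 100000 nM in this assay, at which 2 of the 4 values shown sit. The new step also shows that the number can rise when the entering group, 4-chlorophenyl, has the same count of heavy atoms as the 2-aminophenyl group it replaces, so among the compounds shown a rise does not depend on adding a second phenyl ring.

The compounds shown do not separate the loss of the amino group from the arrival of the chlorine, since both occur in this single change on the carbonyl carbon. From the compounds shown here alone, how a plain phenyl group would stand in this assay, or a methoxy group or a carboxylic acid in place of that chlorine, remains open.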